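This account rests on a few compounds, and the source may have more. Where it says the series, first, only, none or still open, it means among the compounds named here.

Measured compounds in the series:

compound 1 `Fc1ccccc1/C=C/c1ccccc1` — 700 nM
compound 2 `COc1ccccc1/C=C/c1ccccc1F` — 3100 nM
compound 3 `COc1cccc(/C=C/c2ccccc2F)c1` — 3800 nM

In an assay on HepG2 cells for activation of nuclear factor erythroid 2-related factor 2 (Homo sapiens), read by a luciferase reporter, with a stated time of 5 h (on this read-out lower numbers stand for an effect already at smaller amounts and higher numbers for an effect only at larger amounts of compound), compound 1 gives 700 nM, the lowest of the three numbers; compound 2 and compound 3 both sit beyond the scatter above it. Each measured step away from compound 1 adds a methoxy in place of hydrogen on an aromatic carbon, and each moves the number in the same direction: a 4.4-fold higher number from compound 1 to compound 2 (0.65 log units; beyond the scatter) and a 5.4-fold higher number from compound 1 to compound 3 (0.73 log units; beyond the scatter). Both steps are modest and lie close to each other in size.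

Compound 4 `Oc1ccc(/C=C/c2ccccc2F)cc1` differs from compound 1 by hydroxy in place of hydrogen on an aromatic carbon. Going by the values given here, no measured step introduces a hydroxy, so the only steps that bear on this change are the two methoxy additions, which both gave higher numbers. A hydroxy is a smaller group than a methoxy and carries a hydrogen-bond donor the methoxy lacks, so a direct transfer is uncertain; still, a higher number in this assay is the more likely outcome, and a step of the order of a 2.6-fold higher number from compound 1 to compound 4 (0.41 log units; beyond the scatter) is expected. For compound 4 the estimate is 1800 nM, with a range from 600 nM to 6000 nM, the lower end allowing for no change beyond the scatter.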

Compound 4, half-maximal effective concentration: 11400 nM
Beside the measured number, compound 4's estimate is 6.3-fold (0.80 log units) below it; the measured number lies above the stated range.
By their numbers in this assay, from the lowest: compound 1; then compounds 2 and 3 (each within the scatter of the next); then compound 4.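

In this assay the para position relative to the group of 9 heavy atoms proves sensitive: hydroxy in place of hydrogen on this aromatic carbon brings in only 1 heavy atom, yet gives a large step (a 16-fold higher number from compound 1 to compound 4 (1.21 log units; beyond the scatter)). Going by these compounds alone, the two methoxy steps are modest by comparison (a 4.4-fold higher number from compound 1 to compound 2 (0.65 log units; beyond the scatter); a 5.4-fold higher number from compound 1 to compound 3 (0.73 log units; beyond the scatter)), so the size of the entering group does not set the size of the step across these compounds, and all three substitutions on the core of compound 1 move the number the same way, with no compound going against that direction. No measurement at hand bears on why this step is so much larger.

The hydroxy step differs from the methoxy steps in both the group and its place on the core, so the contribution of each remains unresolved, and a methoxy at the same position as the hydroxy of compound 4 would separate them. Also open, from the compounds shown here alone, is whether an amine or a carboxylic acid at this position would follow the hydroxy or the methoxy steps in this assay or depart from both.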